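The source may hold more compounds than are shown below. What is called first, only, known or untested is meant among the compounds shown, and "the series" means these compounds.

Of the compounds shown here, three sharing one core have so far been measured in a functional assay on A549 cells (Homo sapiens) for antiproliferative activity, read by WST assay, with a stated time of 72 h; a lower number here means a stronger inhibitor, a higher number a weaker inhibitor. Compound 1 `Nc1n/c(=N\CCCCc2ccccc2)nc(N)c2c1ncn2Cc1ccccc1` gives 15300 nM. Compound 2 `CCCCCCCCCC/N=c1\nc(N)c2ncn(Cc3ccccc3)c2c(N)n1` gives 1800 nM, and compound 3 `CCCCCCCC/N=c1\nc(N)c2ncn(Cc3ccc(OC)cc3)c2c(N)n1` gives 5700 nM. Compound 3 thus stands second highest of the three numbers: lower than compound 1 and higher than compound 2, both gaps beyond the scatter. Among the measured compounds shown here, the only single-point step among the measured compounds is an 8.5-fold lower number from compound 1 to compound 2 (0.93 log units; beyond the scatter), a change on the chain carbon four bonds from the double-bonded nitrogen and not on the ring.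

Compound 4 `CCCCCCCC/N=c1\nc(N)c2nc[nH]c2c(N)n1` differs from compound 3 by hydrogen in place of 4-methoxybenzyl on an aromatic nitrogen. For the measured compounds named here, no measured pair varies this ring nitrogen, so the one measured step bears on the question only indirectly, by showing that a change on the chain shifted the number by a modest amount. Going by the values given here, with no direct precedent, compound 4 is expected to be a weaker inhibitor than compound 3, a step described by a 3.0-fold higher number from compound 3 to compound 4 (0.47 log units; beyond the scatter) and held with little confidence. Compound 4 is therefore estimated at 17000 nM in this assay, within a range from 4000 nM to 70000 nM.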

Compound 4, half-maximal inhibitory concentration: "not active" (no number reported)
Compound 4: no number reported, so the estimate cannot be set against anything.
By their numbers in this assay, from the lowest: compound 2; then compound 3; then compound 1.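

In this assay, among the compounds shown here, compound 4 is reported as "not active" without a number, so no step from compound 3 to compound 4 can be read. The compounds shown leave open how much the number depends on the 4-methoxybenzyl or any other group on that ring nitrogen. No supporting measurement here bears on this result.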